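Replacing the chlorophenyl amide by a pentyl amide

The source may hold more compounds than are shown below. What is called first, only, known or untested is meant among the compounds shown, and "the series" means these compounds.

Compound 1 `COc1ccc2nc(C)cc(OCC(=O)Nc3ccc(Br)cc3)c2c1` and compound 2 `COc1ccc2nc(C)cc(OCC(=O)Nc3ccc(Cl)cc3)c2c1` share one core and differ only in the halogen on the amide-bound ring; compound 3 `CCCCCNC(=O)COc1cc(C)nc2ccc(OC)cc12` carries a chain there instead. In an ADME assay on HepG2 cells (Homo sapiens) for cytotoxicity, read by trypan blue exclusion, with a stated time of 48 h, in the presence of a further agent that is not named here (a higher number here means that more compound is tolerated, a lower number that less compound is tolerated), compound 1 gives > 125000 nM, which is a limit of the assay and not a number. In this assay compound 2 gives 89900 nM. Among the compounds with values here, the one measured step, an at least 1.3-fold lower number from compound 1 to compound 2 (0.14 log units; that floor lies within the scatter), comes from the exchange of one halogen for another and is within the scatter. Within the data shown here, compound 2 therefore stands as the only numerical value, the other entry being (the limit of > 125000 nM in this assay, at which 1 of the 2 values shown sits). The change toward compound 3 is pentyl in place of 4-chlorophenyl on an amide-type nitrogen. Among the measured compounds shown here, no measured step removes the aromatic ring, so the single halogen swap gives little guidance, and nothing in the data points to a move in either direction beyond the scatter. The number for compound 3 is therefore expected to sit near that of compound 2, with a 1.1-fold higher number from compound 2 to compound 3 (0.05 log units; within the scatter). Compound 3 is estimated at 100000 nM, expected between 40000 nM and 250000 nM.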

Compound 3, half-maximal cytotoxic concentration: > 158000 nM
Compound 3 ended at the assay's limit; the forecaster's own chance of this, stated with the estimate: 35%; at least 1.5-fold (0.19 log units) between middle value and limit.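

In this assay, with pentyl in place of 4-chlorophenyl on an amide-type nitrogen, compound 3 gives > 158000 nM, which is a limit of the assay and not a number. Exchanging the aromatic ring for the open chain gives an at least 1.7-fold higher number from compound 2 to compound 3 (0.24 log units; that floor lies within the scatter), so this position does not need an aromatic ring for the compound to stay at the tolerated end of the read-out, but no real change in tolerance can be claimed from this one step. Only compound 2 carries a number, while compound 1 and compound 3 each stop at a limit, so the step between those two cannot be read: the limit of > 158000 nM in this assay, at which 1 of the 3 values shown sits.

On these data alone, it remains open where the half-maximal cytotoxic concentration of compound 3 actually lies, and whether any group at this nitrogen would give a number clearly lower than that of compound 2. A shorter chain such as propyl, a longer chain such as octyl, or a pentyl chain ending in an amine or a carboxylic acid could each test how far this tolerance of the open chain extends.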